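The source may hold more compounds than are shown below. What is called first, only, known or untested is meant among the compounds shown, and "the series" means these compounds.

The measured compounds:
Compound 1, `N#Cc1cnc(NCc2cnccc2C(F)(F)F)cc1NC[C@H]1C[C@@H](O)C1`, which in an assay on isolated protein for inhibition of protein kinase C delta type (Homo sapiens), read by TR-FRET, with a stated time of 2 h (a lower number here means a stronger inhibitor, a higher number a weaker inhibitor), gives 4200 nM.
Compound 2, `N#Cc1cnc(NCc2cnccc2C(F)(F)F)cc1NCCC1CCOCC1`, which in this assay gives only a limit, > 10000 nM.
Compound 3, `N#Cc1cnc(NCc2cnccc2C(F)(F)F)cc1N[C@H]1CC[C@@H](C(N)=O)CC1`, which in this assay gives 400 nM.

Compound 3 holds the lowest of the two numbers reported; its nearest neighbour is compound 1, and the step is an 11-fold lower number from compound 1 to compound 3 (1.02 log units; beyond the scatter). Compound 2 sits at the limit of > 10000 nM in this assay, at which 1 of the 3 values shown sits, so the step of an at least 25-fold lower number from compound 2 to compound 3 (1.39 log units; beyond the scatter) and the step of an at least 2.3-fold higher number from compound 1 to compound 2 (0.37 log units; beyond the scatter) are bounds rather than numbers. Compound 4, `N#Cc1cnc(NCc2cnccc2C(F)(F)F)cc1N[C@H]1CC[C@@H](n2cncn2)CC1`, differs from compound 3 by 1H-1,2,4-triazol-1-yl in place of carbamoyl on a saturated ring carbon. Among the measured compounds shown here, no measured step changes a group at that position of the cyclohexyl ring: the two steps into compound 3 exchange the whole group on the aromatic nitrogen, and both were large, which shows that this group matters but not what a triazolyl does in place of a carbamoyl. Compound 4 is therefore expected to stay within a modest distance of compound 3, with the greater chance on the weaker side. The estimate for compound 4 in this assay is 1000 nM, between 300 nM and 4000 nM. That estimate means the step of a 2.5-fold higher number from compound 3 to compound 4 (0.40 log units; beyond the scatter) is expected.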

Compound 4, half-maximal inhibitory concentration: 5500 nM
Beside the measured number, compound 4's estimate is 5.5-fold (0.74 log units) below it; measured number outside the range, above it.
By their numbers in this assay, from the lowest: compound 3; then compounds 1 and 4 (each within the scatter of the next). At a limit, above all of these: compound 2.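

In this assay, the group on the saturated ring carbon proves to matter on its own: with the cyclohexyl ring and the rest of the molecule unchanged, 1H-1,2,4-triazol-1-yl in place of carbamoyl gives a 14-fold higher number from compound 3 to compound 4 (1.14 log units; beyond the scatter). The earlier steps shown here exchanged the whole group on the aromatic nitrogen, so they could not separate the ring from what it carries. Here the cyclohexyl ring stays, and the number still rises, so the ring alone does not secure the value of compound 3.

This single change alters the heavy atoms, the hydrogen-bond donors and acceptors and the ring count together, and nothing shown gives a reason for the step. From the compounds shown here alone, whether an amine or a carboxylic acid on that ring carbon would keep the number of compound 3 remains open.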